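Mirror-Image Pyrrolidine: Compound 3 to Compound 4

A few compounds are considered here, and "the series" means these few. Any claim that something is new, unique, unknown or untested is made for them only; others in the source may bear on it.

Three compounds share an aromatic amide and a benzyl-bearing amine and have been tested in an assay on isolated protein for inhibition of sodium channel protein type 4 subunit alpha (Homo sapiens); a lower number here means that less compound is needed, a higher number that more compound is needed for the effect. Compound 1, `Cc1cccc(C)c1NC(=O)[C@H](C)NCc1ccccc1`, gives 9120 nM in this assay. Compound 2, `Cc1cccc(C)c1NC(=O)[C@H]1CCCN1Cc1ccccc1`, gives 31600 nM in this assay. Compound 3, `Cc1cccc(C)c1NC(=O)[C@@H]1CCN(Cc2ccccc2)C1`, gives 1700 nM in this assay, the lowest of the three numbers; compound 1 stands nearest to it, and compound 2 stands furthest, both differences lying beyond the usual scatter.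

Compound 4, `Cc1cccc(C)c1NC(=O)[C@H]1CCN(Cc2ccccc2)C1`, is not yet measured. Compared with compound 3, (the two compounds have the same atoms and bonds and differ only in configuration as drawn: 1 of 1 stereo elements differ; a stereocentre at a saturated ring carbon is drawn R in compound 3 and S in compound 4). The two compounds are thus mirror images at that single centre. Within the data shown here, no pair of measured compounds differs in one place, so no measured step offers a guide to the size of such a change, and nothing in the data says how this assay responds to configuration alone.

For a change that keeps every atom and bond, the account expects a modest effect, if any, and leans toward compound 4 giving a somewhat higher number than compound 3 in this assay, a step of a 2.1-fold higher number from compound 3 to compound 4 (0.31 log units; beyond the scatter). Compound 4 is therefore estimated at 3500 nM in this assay, with a range from 1200 nM to 12000 nM.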

Compound 4, half-maximal effective concentration: 2290 nM
Compound 4: the middle estimate sits 1.5-fold (0.18 log units) above what was measured; the range from low to high includes it.
By their numbers in this assay, from the lowest: compounds 3 and 4 (each within the scatter of the next); then compound 1; then compound 2.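

In this assay, among these compounds, this is the first step between compounds that differ in one place, and it reads a 1.3-fold higher number from compound 3 to compound 4 (0.13 log units; within the scatter). The configuration at the saturated ring carbon, drawn R or S, therefore leaves no readable mark on the number in this assay, and the two mirror-image forms cannot be told apart by it. Because no atom or bond changes, the step isolates that single stereocentre, and the data give it no effect beyond the usual scatter: the fact that compounds 3 and 4 differ only in the configuration as drawn

The compounds shown leave open whether this indifference to configuration would persist with other groups on the shared core, for example if a longer chain took the place of the benzyl group, or if an amine or a carboxylic acid were carried on it. Among the compounds shown here, they also leave open how the number responds to any change of atoms at this position, since the only step available so far concerns configuration alone and says nothing about what a different substituent at that ring carbon would do in this assay.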